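Methyl in Place of Chloro on a Shared Core

The compounds below may be only part of what the source reports. "The series", "measured", "known", "first", "only" and "open" are said of these compounds alone.

Compound 1, `Clc1ccc(Nc2nnc(Cc3ccccc3)o2)cc1`: 31000 nM
Compound 2, `Clc1ccc(Cc2nnc(Nc3ccc(Cl)cc3)o2)cc1`: > 100000 nM
Compound 3, `Clc1ccc(Nc2nnc(Cc3c(Cl)cccc3Cl)o2)cc1Cl`: > 100000 nM

All three compounds were tested in a functional assay on MT2 cells (Homo sapiens) for cytotoxicity, read by MTT assay; a lower number here means that less compound is tolerated, a higher number that more compound is tolerated. Compound 1 gives 31000 nM. Compound 2 gives > 100000 nM, which is a limit of the assay and not a number. Compound 3 likewise gives > 100000 nM, again a limit rather than a number, so that compound 3 stands at the limit of > 100000 nM in this assay, at which 2 of the 3 values shown sit. Going by the values given here, the one measured step, an at least 3.2-fold higher number from compound 1 to compound 2 (0.50 log units; beyond the scatter), describes chloro in place of hydrogen on an aromatic carbon.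

Compound 4, `Cc1cc(Nc2nnc(Cc3c(Cl)cccc3Cl)o2)ccc1Cl`, has not yet been measured in this assay. Its difference from compound 3 is methyl in place of chloro on an aromatic carbon. No measured step covers an exchange of methyl for chloro, so the direction and size of this change are not anchored by anything shown here. Because compound 3 gives > 100000 nM, compound 4 is expected to remain close to that limit, with the chance that this assay once more reports only a limit. The expected step is a number no higher from compound 3 to compound 4 (the limit leaves the size open), well within the scatter. Compound 4 is therefore estimated at 100000 nM, in a range from 40000 nM to 250000 nM.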

Compound 4, half-maximal cytotoxic concentration: > 100000 nM
Compound 4: only a limit was reported; the forecaster's own chance of this, stated with the estimate: 60%; the middle value lies on the limit itself.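

Compound 3 and compound 4 both stand at a limit of this assay rather than at a number, so no step between them can be read: the limit of > 100000 nM in this assay, at which 3 of the 4 values shown sit.

The compounds shown leave open whether methyl in place of chloro on an aromatic carbon changes the number in this assay at all, and, if it does, in which direction and by how much.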